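The source may hold more compounds than are shown below. What is called first, only, known or untested is meant among the compounds shown, and "the series" means these compounds.

Measured so far in a functional assay on A549 cells (Homo sapiens) for antiproliferative activity, read by MTT assay; a higher number here means a weaker inhibitor, a lower number a stronger inhibitor:
- compound 1, `COc1cc2c(Oc3ccc(NC(=O)Nc4ccccc4C(F)(F)F)cc3)ccnc2cc1OCCCCCCC(=O)NO`: 5280 nM
- compound 2, `COc1ccccc1NC(=O)Nc1ccc(Oc2ccnc3cc(OCCCCCCC(=O)NO)c(OC)cc23)cc1`: 16200 nM

Compound 1 holds the lower of the two numbers in this assay; compound 2 is the nearest and only other point, and the step between them is a 3.1-fold higher number from compound 1 to compound 2 (0.49 log units; beyond the scatter). For the measured compounds named here, that is the one measured change in the set: methoxy in place of trifluoromethyl on an aromatic carbon.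

Compound 3, `COc1cc2c(Oc3ccc(NC(=O)NNC(=O)c4ccccc4F)cc3)ccnc2cc1OCCCCCCC(=O)NO`, is not yet measured. It differs from compound 1 as follows: ((2-fluorophenyl)carbonyl)amino in place of 2-(trifluoromethyl)phenyl on an amide-type nitrogen. The measured step bears on this only loosely: it shows that a small exchange on an aromatic carbon already moved the number by a 3.1-fold higher number from compound 1 to compound 2 (0.49 log units; beyond the scatter), whereas here a whole group leaves the amide-type nitrogen and a different one enters. Going by the values given here, no measured pair covers such an exchange. Relative to compound 1, the number for compound 3 is expected to move by a 1.9-fold higher number from compound 1 to compound 3 (0.28 log units; within the scatter), with wide uncertainty. Compound 3 is expected to give 10000 nM in this assay, within 3000 nM to 40000 nM.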

Compound 3, half-maximal inhibitory concentration: 2420 nM
For compound 3 the middle estimate is 4.1-fold (0.62 log units) above the measured one; measured number below the stated range.
By their numbers in this assay, from the lowest: compound 3; then compound 1; then compound 2.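

In this assay the amide-type nitrogen accepts more than a directly attached aryl group: ((2-fluorophenyl)carbonyl)amino gives a 2.2-fold lower number from compound 1 to compound 3 (0.34 log units; beyond the scatter) and, in place of 2-methoxyphenyl, a 6.7-fold lower number from compound 2 to compound 3 (0.83 log units; beyond the scatter) in the same direction. The earlier pair showed only an exchange on an aromatic carbon, whereas these steps show that inserting a carbonyl and a further nitrogen ahead of the aromatic ring lowers the number against both aryl ureas shown. No measurement here explains this gain.

On these data alone, compound 3 changes the link and the ring substituent at once, so the share of each in the step stays open. Also open, as far as these compounds go, is how a pyridine ring or a chlorine on the aromatic ring would read on this carbonylamino link.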